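Fluoro to hydrogen on the piperidinyl ring of compound 2

The source may hold more compounds than are shown below. What is called first, only, known or untested is meant among the compounds shown, and "the series" means these compounds.

Compound 1 `CC1CCCC(C(=O)N2CC(c3nc(-c4cccc(Cl)c4)no3)C2)C1`: > 10000 nM
Compound 2 `O=C(N1CCC(F)CC1)N1CC(c2nc(-c3cccc(Cl)c3)no2)C1`: > 10000 nM

Both measured compounds were tested in an assay on HEK293 cells for negative allosteric modulation of metabotropic glutamate receptor 5 (Homo sapiens), read by FLIPR; a lower number here means a stronger inhibitor, a higher number a weaker inhibitor. For compound 1 the assay reports only a limit, > 10000 nM. For compound 2 the result is likewise a limit, > 10000 nM. Between them lies a step whose size cannot be read: a step that the two limits leave unreadable from compound 1 to compound 2. Compound 2 therefore stands at the limit of this assay, the same place where every value shown sits (the limit of > 10000 nM in this assay, at which 2 of the 2 values shown sit).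

Compound 3 `O=C(N1CCCCC1)N1CC(c2nc(-c3cccc(Cl)c3)no2)C1` differs from compound 2 by hydrogen in place of fluoro on a saturated ring carbon. Within the data shown here, no measured step bears on this change, and the one step that was measured is unreadable, so the data give no direction for it. With compound 2 at the limit, compound 3 is expected to remain there as well. The estimated step from compound 2 to compound 3 is a step that the limit leaves unreadable from compound 2 to compound 3. Compound 3 is expected to give 15000 nM in this assay, in the range 4000 nM to 60000 nM, most likely reported again as a limit.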

Compound 3, half-maximal inhibitory concentration: > 10000 nM
Compound 3: no number, only a limit (the forecaster's own chance of this, stated with the estimate: 80%); the middle value lies beyond the limit too.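

Compound 1, compound 2 and compound 3 all give only a limit in this assay, so no step among them can be read: the limit of > 10000 nM in this assay, at which 3 of the 3 values shown sit.

The compounds shown leave open whether exchanging 3-methylcyclohexyl, 4-fluoropiperidin-1-yl or piperidin-1-yl on the carbonyl carbon changes inhibition at all.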